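Aryl variation on the fused core: compound 3 to compound 4

This account rests on a few compounds, and the source may have more. Where it says the series, first, only, none or still open, it means among the compounds named here.

Measured compounds:
compound 1 `COc1ccc(-c2cc3nccc(-c4cc(OC)c(OC)c(OC)c4)n3n2)cc1N` — 138 nM
compound 2 `COc1cc(-c2ccnc3cc(-c4ccc(N(C)C)cc4)nn23)cc(OC)c1OC` — 1100 nM
compound 3 `COc1cc(-c2ccnc3cc(-c4cccc(C)c4)nn23)cc(OC)c1OC` — 5730 nM

In a functional assay on A549 cells (Homo sapiens) for inhibition, read by CCK-8 assay, with a stated time of 48 h (a lower number here means a stronger inhibitor, a higher number a weaker inhibitor), compound 3 stands highest of the three numbers; its nearest neighbour is compound 2 and its furthest is compound 1, both beyond the scatter, as a 5.2-fold higher number from compound 2 to compound 3 (0.72 log units; beyond the scatter) and a 42-fold higher number from compound 1 to compound 3 (1.62 log units; beyond the scatter) show.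

Compound 4 `COc1cc(-c2ccnc3cc(-c4ccc(C(F)(F)F)cc4)nn23)cc(OC)c1OC` is not yet measured. The change is 4-(trifluoromethyl)phenyl in place of 3-methylphenyl on an aromatic carbon, at the place on the five-membered ring next to the ring nitrogen.

For the measured compounds named here, no measured step swaps a methyl for a trifluoromethyl; the steps 1>3 and 2>3 each replace an amino-bearing phenyl, so they bear only loosely here. A step within the scatter is therefore expected in this assay, and compound 4 is estimated at 6500 nM, range 2500 nM to 17000 nM, meaning a 1.1-fold higher number from compound 3 to compound 4 (0.05 log units; within the scatter).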

Compound 4, half-maximal inhibitory concentration: 2070 nM
The estimate for compound 4 lay 3.1-fold (0.50 log units) above the measured number; measured number outside the range, below it.
By their numbers in this assay, from the lowest: compound 1; then compounds 2 and 4 (each within the scatter of the next); then compound 3.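

In this assay this position accepts a phenyl with no nitrogen on it: 4-(trifluoromethyl)phenyl improves on 3-methylphenyl (a 2.8-fold lower number from compound 3 to compound 4 (0.44 log units; beyond the scatter)) and matches the dimethylamino analogue within the scatter (a 1.9-fold higher number from compound 2 to compound 4 (0.27 log units; within the scatter)). An amino-bearing ring is therefore not needed to reach that level, though 3-amino-4-methoxyphenyl still stands well apart (a 15-fold higher number from compound 1 to compound 4 (1.18 log units; beyond the scatter)). Nothing measured here accounts for these steps.

Open, on these data alone, is whether 4-methylphenyl or 3-(trifluoromethyl)phenyl would separate the effect of the group from that of its place on the phenyl ring. Also open, as far as these compounds go, is whether 3-aminophenyl, without the methoxy, would keep the number of compound 1.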